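Removing bromine from two related cores in a growth assay

A few compounds are considered here, and "the series" means these few. Any claim that something is new, unique, unknown or untested is made for them only; others in the source may bear on it.

Measured so far:
Compound 1, `O=C1C(=O)N(CN2CCN(c3ccnc4cc(Cl)ccc34)CC2)c2cc(Br)ccc21`: 18000 nM
Compound 2, `O=C1C(=O)N(CN2CCN(c3ccnc4cc(Cl)ccc34)CC2)c2ccccc21`: 45900 nM
Compound 3, `NC(=S)N/N=C1/C(=O)N(CN2CCN(c3ccnc4cc(Cl)ccc34)CC2)c2cc(Br)ccc21`: 22100 nM

All three were run in an ADME assay on MCF-10A cells (Homo sapiens) for cytotoxicity, read by sulforhodamine B assay, with a stated time of 48 h; a lower number here means a stronger inhibitor of growth, a higher number a weaker inhibitor of growth. Compound 1 gives 18000 nM, and compound 2 gives 45900 nM. The two differ by hydrogen in place of bromo on an aromatic carbon, and this change made a step of a 2.6-fold higher number from compound 1 to compound 2 (0.41 log units; beyond the scatter).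

Compound 3 carries a different core; the difference between the two cores is not broken down here. In this assay compound 3 gives 22100 nM, which lies within the scatter of compound 1 and beyond it from compound 2.

Compound 4, `NC(=S)N/N=C1/C(=O)N(CN2CCN(c3ccnc4cc(Cl)ccc34)CC2)c2ccccc21`, has not yet been measured. It differs from compound 3 by hydrogen in place of bromo on an aromatic carbon, the same change that separates compound 1 from compound 2, made at the same place on the ring. The expectation for compound 4 rests on that earlier step: since compound 3 gives 22100 nM, a step of about the size of a 2.6-fold higher number from compound 1 to compound 2 (0.41 log units; beyond the scatter) is expected, so that a 2.4-fold higher number from compound 3 to compound 4 (0.37 log units; beyond the scatter) is estimated. For compound 4 a value of 52000 nM is expected, in the range 25000 nM to 110000 nM.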

Compound 4, concentration for 50% growth inhibition: 27700 nM
Compound 4: the middle estimate sits 1.9-fold (0.27 log units) above what was measured; measured number inside the range.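

In this assay, replacing bromo with hydrogen on the second core gave a 1.3-fold higher number from compound 3 to compound 4 (0.10 log units; within the scatter), a step that, unlike the one on the first core, does not stand clear of the scatter. Even so, the two steps cannot be told apart: the same change on two cores in this assay, a 2.6-fold higher number (0.41 log units; beyond the scatter) from compound 1 to compound 2 and a 1.3-fold higher number (0.10 log units; within the scatter) from compound 3 to compound 4, 2.0-fold (0.31 log units) apart, within the scatter of two such steps. For the compounds shown here, this gives no sign that the change behaves differently from one core to the other, but it does not show that the step carries over unchanged either, as the comparison rests on only two pairs and only one of the two steps is beyond the scatter.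

The compounds shown leave open how either core would respond to a group other than bromo or hydrogen at this place on the ring, such as chloro, methoxy or an amine. They also leave open whether any such group would move the two cores by similar amounts, or whether a difference between the cores would then emerge.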